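Swapping the thioether aryl group on a dibromophenol pyrazoline

The source may report more compounds than this note shows. Statements on the series, on what has been measured and on what is new or still open speak of the compounds shown alone.

This account follows three pyrazoline thioether amides and one untested relative. Compound 1 `CC1=NN(C(=O)CSc2ccccc2)[C@@H](c2cc(Br)cc(Br)c2O)C1` gives 10400 nM in a functional assay on HepG2 cells (Homo sapiens) for cytotoxicity, read by MTT assay, with a stated time of 48 h; on this read-out lower numbers stand for stronger inhibition and higher numbers for weaker inhibition. Compound 2 `CC1=NN(C(=O)CSc2nc3ccccc3s2)[C@@H](c2cc(Br)cc(Br)c2O)C1` gives 8700 nM in this assay, the lowest of the three numbers, though the gap to compound 1 is within the scatter: a 1.2-fold lower number from compound 1 to compound 2 (0.08 log units; within the scatter). Compound 3 `O=C(CSc1ccc(Br)cc1)N1N=C(c2cc3ccccc3oc2=O)C[C@@H]1c1ccccc1`, which carries a different core but shares a 4-bromophenyl on its sulfur, gives 14500 nM.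

Compound 4 `CC1=NN(C(=O)CSc2ccc(Br)cc2)[C@@H](c2cc(Br)cc(Br)c2O)C1` has not yet been measured. It differs from compound 2 in one place: 4-bromophenyl in place of 1,3-benzothiazol-2-yl on a sulfur. Within the data shown here, the only measured step that changes the aryl group on that sulfur, from compound 1 to compound 2, stayed within the scatter, and compound 3 shows that a 4-bromophenyl on the sulfur is compatible with a number of the same order. Compound 4 is therefore expected to move no further than the scatter, a 1.2-fold higher number from compound 2 to compound 4 (0.08 log units; within the scatter). Compound 4 is estimated at 10500 nM, with a range from 5000 nM to 22000 nM.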

Compound 4, half-maximal inhibitory concentration: 6870 nM
Compound 4: middle estimate off by 1.5-fold (0.18 log units), on the high side; low and high end bracket the measured number.
By their numbers in this assay, from the lowest: compounds 4, 2, 1 and 3 (each within the scatter of the next, the first and the last beyond it).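

The step to 4-bromophenyl on the sulfur gives a 1.3-fold lower number from compound 2 to compound 4 (0.10 log units; within the scatter) in this assay, so a third aryl group at this position joins the other two without a step beyond the scatter. Bromo in place of hydrogen on an aromatic carbon, a change the earlier compounds did not offer on this core, gives a 1.5-fold lower number from compound 1 to compound 4 (0.18 log units; within the scatter) and also stays within the scatter. Phenyl, 4-bromophenyl and 1,3-benzothiazol-2-yl on this sulfur therefore cannot be told apart here, although only the last carries hydrogen-bond acceptors.

Nothing measured alongside these numbers bears on why the steps stay this small. From the compounds shown here alone, it remains open whether an amine or a carboxylic acid on the aryl ring, or a longer chain in place of that ring, would give a step beyond the scatter.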